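Carbamoyl in place of the ring group of compound 3

The source may report more compounds than this note shows. Statements on the series, on what has been measured and on what is new or still open speak of the compounds shown alone.

Within the data shown here, in an ADME assay on microsomes from liver (Mus musculus) for metabolic stability (a lower number here means that the compound disappears faster, a higher number that the compound lasts longer), compound 3 (`CC(C)C(Cc1noc(=O)[nH]1)c1ccc(-c2ccc3cccc(F)c3c2)[nH]c1=O`) gives 2.78 h, the only true number so far. Compound 1 (`CC(C)C(Cc1ncc[nH]1)c1ccc(-c2ccc3cccc(F)c3c2)[nH]c1=O`) reads < 0.0667 h, which is a limit of the assay and not a number. Compound 2 (`CC(C)C(Cc1nnc[nH]1)c1ccc(-c2ccc3cccc(F)c3c2)[nH]c1=O`) reads < 0.0667 h, which is also a limit.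

Compound 4 (`CC(C)C(CC(N)=O)c1ccc(-c2ccc3cccc(F)c3c2)[nH]c1=O`) differs from compound 3 by a group of 3 heavy atoms (1 carbon, 1 nitrogen, 1 oxygen; no ring) in place of a group of 6 heavy atoms (2 carbon, 2 nitrogen, 2 oxygen; one five-membered aromatic ring with 3 hetero atoms), on a saturated chain carbon, two bonds along the chain from an aromatic carbon. Among the measured compounds shown here, two measured steps bear on this change, as both replace the group at the same place: an at least 41-fold higher number from compound 1 to compound 3 (1.61 log units; beyond the scatter) and an at least 41-fold higher number from compound 2 to compound 3 (1.61 log units; beyond the scatter). Going by these compounds, both are large and beyond the scatter, and their full size stays open because of the limit of < 0.0667 h in this assay, at which 2 of the 3 values shown sit. Read backwards, they show that in the two cases seen, replacing the group of compound 3 left the half-life at the limit. Neither case has an open-chain group such as carbamoyl, so they guide the direction better than the size. A fall is therefore expected, but a smaller one than those two steps imply.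

The expected change is a 4.6-fold lower number from compound 3 to compound 4 (0.67 log units; beyond the scatter), an estimate with wide uncertainty. The estimated value for compound 4 is 0.6 h, with an expected range of 0.1 h to 3 h.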

Compound 4, half-life: < 0.0667 h
Compound 4 gave a limit, no number; the forecaster's own chance of this, stated with the estimate: 15%; at least 8.9-fold (0.95 log units) between middle value and limit.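

Replacing the ring group with carbamoyl on the saturated chain carbon gives an at least 41-fold lower number from compound 3 to compound 4 (1.61 log units; beyond the scatter). An open-chain group at this place therefore joins 1H-imidazol-2-yl and 4H-1,2,4-triazol-3-yl at the limit, and among the four compounds shown, only compound 3 gives a true number in this assay. The steps among compound 1, compound 2 and compound 4 cannot be read, and no order among these three can be drawn because of their shared limit: the limit of < 0.0667 h in this assay, at which 3 of the 4 values shown sit.

The series does not show whether a carboxylic acid or a tetrazole at the same place on the saturated chain carbon would give a true number in this assay or would also sit at the limit. It also leaves open whether a longer chain carrying the carbamoyl would differ from compound 4, and so how much of the half-life of compound 3 depends on the five-membered ring with its carbonyl.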